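Swapping a Cycloalkyl Amide Tail for a Quinolinyl Amine

The source may report more compounds than this note shows. Statements on the series, on what has been measured and on what is new or still open speak of the compounds shown alone.

Measured compounds:
compound 1 `O=C(CC1CCCCCC1)N1CCC(c2nc(-c3ccc4ccccc4n3)no2)CC1`: 840 nM
compound 2 `O=C(NC1CCCCC1)N1CCN(c2nc(-c3ccc4ccccc4n3)no2)CC1`: 53 nM
compound 3 `Cn1c(-c2noc(C3CCN(C(=O)NC4CCS(=O)(=O)CC4)CC3)n2)nc2ccccc21`: 350 nM

These three compounds were tested in a functional assay on Shh Light II cells (Mus musculus) for inhibition, read by a luciferase reporter; a higher number here means a weaker inhibitor, a lower number a stronger inhibitor. Of the three, compound 1 gives the highest number, 840 nM, so it is the weakest inhibitor shown; its nearest neighbour is compound 3 with 350 nM, and the gap to compound 2 at 53 nM is the largest, both gaps lying beyond the scatter.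

Compound 4 `O=C(Nc1cccc2cccnc12)N1CCC(c2nc(-c3ccc4ccccc4n3)no2)CC1` has not yet been measured. It differs from compound 1 in one place: (quinolin-8-yl)amino in place of cycloheptylmethyl on a carbonyl carbon. Among the measured compounds shown here, compound 2 and compound 3 both carry an amino group on the carbonyl carbon, as compound 4 will, and both give lower numbers than compound 1; no single-change step is available, so this is only a pointer. On that basis a step downward beyond the scatter is expected, a 5.6-fold lower number from compound 1 to compound 4 (0.75 log units; beyond the scatter). For compound 4 the expected value in this assay is 150 nM, most likely between 40 nM and 600 nM.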

Compound 4, half-maximal inhibitory concentration: 1400 nM
For compound 4 the middle estimate is 9.3-fold (0.97 log units) below the measured one; the whole stated range lies below it.
By their numbers in this assay, from the lowest: compound 2; then compound 3; then compounds 1 and 4 (each within the scatter of the next).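

In this assay, putting (quinolin-8-yl)amino in place of cycloheptylmethyl on the carbonyl carbon gives a 1.7-fold higher number from compound 1 to compound 4 (0.22 log units; within the scatter), so the two compounds cannot be told apart. At this position, a change from a seven-membered carbon ring to two aromatic rings, with a hydrogen-bond donor and acceptor added, leaves the reading within the scatter, and an amino group on this carbonyl carbon does not by itself give a lower number. No available measurement bears on why the two groups read alike.

Going by these compounds, it remains open whether the amino link and the quinolin-8-yl ring system each matter alone, and a cycloheptylamino group on the same carbonyl carbon would test the first of these. A quinolin-8-ylmethyl group there would test the second.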